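Methoxy Addition on a Lactone and a Lactam Series

The compounds below may be only part of what the source reports. "The series", "measured", "known", "first", "only" and "open" are said of these compounds alone.

Measured so far:
compound 1 `COc1ccc(/C=C/C2CC=CC(=O)O2)c(OC)c1` gives 8.8 uM
compound 2 `COc1cc(OC)c(OC)cc1/C=C/C1CC=CC(=O)O1` gives 9.4 uM
compound 3 `COc1ccc(/C=C/C2CC=CC(=O)N2)cc1` gives 842 uM

All three compounds were tested in a functional assay on NCI/ADR cells (Homo sapiens) for inhibition, read by sulforhodamine B assay, with a stated time of 48 h; on this read-out higher numbers stand for weaker inhibition of growth and lower numbers for stronger inhibition of growth. Compound 1 and compound 2 give similar numbers, and the step of a 1.1-fold higher number from compound 1 to compound 2 (0.03 log units; within the scatter) is the result of the change (methoxy in place of hydrogen on an aromatic carbon). Compound 3 stands apart: in this assay compound 3 gives 842 uM, far higher than either of the other two. The difference between the core of compound 3 and the core of compound 1 is not broken down here.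

Compound 4 `COc1ccc(/C=C/C2CC=CC(=O)N2)cc1OC` has not been measured. It differs from compound 3 by methoxy in place of hydrogen on an aromatic carbon. This is the same kind of change as that from compound 1 to compound 2, though the surroundings are not identical: in the pair of compound 1 and compound 2 the entering methoxy is also para to a methoxy group, whereas in the pair of compound 3 and compound 4 it is not.

For the measured compounds named here, the only measured example of this kind of change, the step from compound 1 to compound 2, stayed within the scatter. On that basis the step of a 1.1-fold lower number from compound 3 to compound 4 (0.05 log units; within the scatter) is expected to be small as well, because compound 3 already gives 842 uM and the added methoxy has shown little effect elsewhere. Compound 4 is therefore estimated to give 750 uM in this assay, with a range from 250 uM to 2200 uM.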

Compound 4, concentration for growth inhibition (reported as GI): > 964 uM
Compound 4: a limit, no number; the forecaster's own chance of this, stated with the estimate: 25%; middle value at least 1.2-fold (0.10 log units) away from the limit.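

In this assay compound 4 gives > 964 uM as a limit of the assay and not a number. Placing methoxy in place of hydrogen on an aromatic carbon of the core of compound 3 therefore yields only a floor for the step, an at least 1.1-fold higher number from compound 3 to compound 4 (0.05 log units; that floor lies within the scatter) and not its full size, and the comparison with the earlier step on the other core reads: the same change on two cores in this assay, a 1.1-fold higher number (0.03 log units; within the scatter) from compound 1 to compound 2 and an at least 1.1-fold higher number (0.05 log units; that floor lies within the scatter) from compound 3 to compound 4; the limit leaves it open whether they differ. For the compounds shown here, this shows that nothing measured so far speaks against a small effect of this change on both cores, but it does not show that the change carries over unaltered, since the true step on the second core could be small or much larger.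

The compounds shown carry only methoxy groups on the aromatic ring, leaving open how a chlorine, a hydroxyl or an amine in that place would read on either core. Going by these compounds alone, they also hold no pair that differs in the core alone, and a methyl group in place of the amide hydrogen of compound 3 is among the changes whose outcome remains unknown.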